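The source may hold more compounds than are shown below. What is called first, only, known or untested is meant among the compounds shown, and "the series" means these compounds.

Values measured in a functional assay on K562 cells (Homo sapiens), read by MTT assay, with a stated time of 72 h; a lower number here means a stronger inhibitor, a higher number a weaker inhibitor:

Compound 1 `COc1ncnc2c1c(-c1ccccc1)cn2[C@@H]1O[C@H](CO)[C@@H](O)[C@H]1O`: > 20000 nM, a limit
Compound 2 `CSc1ncnc2c1c(-c1ccoc1)cn2[C@@H]1O[C@H](CO)[C@@H](O)[C@H]1O`: 60 nM
Compound 3 `CNc1ncnc2c1c(-c1ccoc1)cn2[C@@H]1O[C@H](CO)[C@@H](O)[C@H]1O`: > 20000 nM, a limit

Compound 3 has no number in this assay, only (the limit of > 20000 nM in this assay, at which 2 of the 3 values shown sit). Compound 4 `C#Cc1cn([C@@H]2O[C@H](CO)[C@@H](O)[C@H]2O)c2ncnc(NC)c12` is derived from it by one change, ethynyl in place of furan-3-yl on an aromatic carbon of a five-membered aromatic ring with 1 nitrogen: ethynyl in place of furan-3-yl on an aromatic carbon. Compound 4 has not yet been measured.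

Within the data shown here, no measured step alters the group at this place, so the data give no direct size for the exchange. Among the measured compounds shown here, the one measured step, an at least 330-fold higher number from compound 2 to compound 3 (2.52 log units; beyond the scatter), is large and beyond the scatter. It is methylamino in place of methylsulfanyl on an aromatic carbon, and compound 4 keeps that methylamino group. Compound 4 is therefore expected to remain weak in this assay, with at most a modest move towards a lower number, and it may well stay at the limit.

The expected change is an at least 2.5-fold lower number from compound 3 to compound 4 (0.39 log units; beyond the scatter). For compound 4 the estimated value is 8000 nM, with an expected range of 600 nM to 20000 nM.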

Compound 4, half-maximal inhibitory concentration: > 20000 nM
Compound 4 was reported as a limit; the forecaster's own chance of this, stated with the estimate: 55%; at least 2.5-fold (0.39 log units) between middle value and limit.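

In this assay compound 4 gives > 20000 nM as a limit. Compound 3 also stands at a limit, so the exchange of furan-3-yl for ethynyl between compound 3 and compound 4 cannot be read: the limit of > 20000 nM in this assay, at which 3 of the 4 values shown sit.

The compounds shown leave open how ethynyl and furan-3-yl compare in this assay when the methylsulfanyl group of compound 2 is present.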